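The source may report more compounds than this note shows. Statements on the series, on what has been measured and on what is new or still open speak of the compounds shown alone.

Compound 1 `COc1ncc(-c2ccc3nc(NC(=O)NCCN(C)C)sc3c2)cc1NS(=O)(=O)c1ccc(F)cc1`: 240 nM
Compound 2 `CCN(CC)CCNC(=O)Nc1nc2ccc(-c3cnc(OC)c(NS(=O)(=O)c4ccc(F)cc4)c3)cc2s1`: 300 nM

In a functional assay on HCT-116 cells (Homo sapiens) for antiproliferative activity, read by MTT assay, with a stated time of 72 h (on this read-out higher numbers stand for weaker inhibition and lower numbers for stronger inhibition), compound 2 holds the highest of the two numbers, its nearest neighbour being compound 1, which differs by a 1.3-fold higher number from compound 1 to compound 2 (0.10 log units; within the scatter). Compound 3 `COc1ncc(-c2ccc3nc(NC4CC4)sc3c2)cc1NS(=O)(=O)c1ccc(F)cc1` takes the next step: cyclopropyl in place of (2-(diethylamino)ethyl)carbamoyl on a nitrogen on an aromatic ring. No measured step touches this change; the one step shown, a 1.3-fold higher number from compound 1 to compound 2 (0.10 log units; within the scatter), alters only the amine at the chain end and stays within the scatter, so it offers no guide to removing the whole chain. Compound 3 is therefore estimated, with wide uncertainty, at 700 nM (range 150 nM to 3500 nM), a step of a 2.3-fold higher number from compound 2 to compound 3 (0.37 log units; beyond the scatter) being expected.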

Compound 3, half-maximal inhibitory concentration: 1560 nM
Compound 3: middle estimate off by 2.2-fold (0.35 log units), on the low side; measured number inside the range.
By their numbers in this assay, from the lowest: compounds 1 and 2 (each within the scatter of the next); then compound 3.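

In this assay, among these compounds, the change on this nitrogen on an aromatic ring is the first to move the number beyond the scatter, with a 5.2-fold higher number from compound 2 to compound 3 (0.72 log units; beyond the scatter) and a 6.5-fold higher number from compound 1 to compound 3 (0.81 log units; beyond the scatter). Inhibition thus weakens when cyclopropyl replaces either whole carbamoyl chain, whereas the two terminal amines alone gave no such separation. No measurement given here explains this loss. The compounds shown leave open whether the loss follows the carbonyl, the chain or its terminal amine. A simple acetyl group, a (2-methoxyethyl)carbamoyl chain or a morpholine at the chain end could separate these parts.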